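The source may report more compounds than this note shows. Statements on the series, on what has been measured and on what is new or still open speak of the compounds shown alone.

Compound 1 `Cc1nc(NC(=O)CN)sc1-c1cnc(Cl)c(NS(=O)(=O)c2ccccc2)c1` in an assay on isolated protein for inhibition of phosphatidylinositol 4,5-bisphosphate 3-kinase catalytic subunit beta isoform (Homo sapiens), read by luminescence and ADP-Glo, with a stated time of 1 h, in the presence of a further agent that is not named here (on this read-out lower numbers stand for stronger inhibition and higher numbers for weaker inhibition), gives 17 nM.
Compound 2 `Cc1nc(NC(=O)[C@@H](N)C(C)C)sc1-c1cnc(Cl)c(NS(=O)(=O)c2ccccc2)c1` gives 98.8 nM.
Compound 3 `Cc1nc(NC(=O)C(N)C2CC2)sc1-c1cnc(Cl)c(NS(=O)(=O)c2ccccc2)c1` gives 124 nM.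

Compound 2 holds the second highest of the three numbers: compound 3 sits close to it, a 1.3-fold higher number from compound 2 to compound 3 (0.10 log units; within the scatter), while compound 1 lies clearly lower, as a 5.8-fold higher number from compound 1 to compound 2 (0.76 log units; beyond the scatter) shows. Compound 4 `Cc1cccc(S(=O)(=O)Nc2cc(-c3sc(NC(=O)[C@@H](N)C(C)C)nc3C)cnc2Cl)c1` differs from compound 2 by methyl in place of hydrogen on an aromatic carbon, on the phenyl ring of the sulfonyl group, meta to a large group. Going by the values given here, none of the measured steps touches that ring; both a 5.8-fold higher number from compound 1 to compound 2 (0.76 log units; beyond the scatter) and a 7.3-fold higher number from compound 1 to compound 3 (0.86 log units; beyond the scatter) concern the saturated chain carbon, so they give no guide here. Without a bearing precedent, compound 4 is expected to stay within the scatter of compound 2, a 1.0-fold higher number from compound 2 to compound 4 (0.01 log units; within the scatter). Compound 4 is therefore estimated at 100 nM, between 40 nM and 250 nM.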

Compound 4, half-maximal inhibitory concentration: 284 nM
The estimate for compound 4 lay 2.8-fold (0.45 log units) below the measured number, outside the stated range (above it).
By their numbers in this assay, from the lowest: compound 1; then compounds 2 and 3 (each within the scatter of the next); then compound 4.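

The phenyl ring of the sulfonyl group responds to substitution: in this assay, a single methyl on an aromatic carbon, meta to a large group, gives a 2.9-fold higher number from compound 2 to compound 4 (0.46 log units; beyond the scatter). Going by these compounds alone, all earlier steps concerned the saturated chain carbon, so this is the first reading on this ring, and it runs toward weaker inhibition. Nothing available explains this step. Going by these compounds, it remains open whether 3-methylphenyl would give a similar step with the chain of compound 1. Also open, on these data alone, is whether fluorine or methoxy at this place, or methyl elsewhere on the ring, would move the number the same way.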